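The compounds below may be only part of what the source reports. "The series", "measured", "known", "first", "only" and "open" are said of these compounds alone.

Measured so far:

compound 1, `O=C(O)c1ccc(CN2CCC[C@H](O[C@H](CO)c3cc(Cl)cc(Cl)c3)[C@@H]2c2ccccc2)cc1`, gives 11000 nM in an assay on isolated protein for activation of cGMP-dependent protein kinase 1 (Homo sapiens), read by ADP-Glo, with stated times of 120 min and 40 min; a higher number here means that more compound is needed for the effect, a lower number that less compound is needed.
compound 2, `Clc1cc(Cl)cc(CO[C@H]2CCCN(Cc3nccs3)[C@H]2c2ccccc2)c1`, gives > 200000 nM in this assay, and this is a limit of the assay, not a number.

Compound 2 thus stands at the limit of > 200000 nM in this assay, at which 1 of the 2 values shown sits. Going by the values given here, nothing more is known of it than that it lies at that edge, so no step between compound 1 and compound 2 can be given here; the two values shown simply differ, one a number and one a limit.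

Compound 3, `Cn1ccnc1CN1CCC[C@H](OCc2cc(Cl)cc(Cl)c2)[C@@H]1c1ccccc1`, has not been measured in this assay. It differs from compound 2 at one place:

1-methyl-1H-imidazol-2-yl in place of 1,3-thiazol-2-yl on a saturated chain carbon bound to an amine nitrogen in a ring

The place of attachment is the same, and one small aromatic ring is exchanged for another of the same kind.

Among the compounds with values here, with no measured step of this kind at hand, the step from compound 2 to compound 3 in this assay is expected to be none beyond the scatter, and the estimated step of a number no higher from compound 2 to compound 3 (the limit leaves the size open) reflects that. Compound 3 is therefore estimated at 200000 nM, within a range from 50000 nM to 600000 nM, and most likely the assay would again report only a limit.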

Compound 3, half-maximal effective concentration: 165000 nM
For compound 3 the middle estimate is 1.2-fold (0.08 log units) above the measured one; the measured number falls inside the stated range.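

Compound 3 brings a readable number to this place, on a saturated chain carbon bound to an amine nitrogen in a ring: in this assay compound 3 gives 165000 nM and thus offers a first measured point for this pair. Exchanging 1,3-thiazol-2-yl for 1-methyl-1H-imidazol-2-yl gives an at least 1.2-fold lower number from compound 2 to compound 3 (0.08 log units; that floor lies within the scatter) in this single change of one small aromatic ring for another. Only this floor can be stated, not the true size of the step, because one end of the step is a limit of the assay and not a number: the limit of > 200000 nM in this assay, at which 1 of the 3 values shown sits.

From the compounds shown here alone, how far compound 2 really lies from compound 3 stays open, and with it whether this exchange does anything beyond the scatter. Also open is whether a pyridin-2-yl ring or an open chain ending in a primary amine at the same place would give a different reading in this assay, since the compounds shown cover only two small aromatic rings in a direct comparison.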